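The source may report more compounds than this note shows. Statements on the series, on what has been measured and on what is new or still open speak of the compounds shown alone.

Three compounds built on one shared core have been examined in a functional assay on Huh-7 cells (Homo sapiens) for inhibition, read by sulforhodamine B assay, with a stated time of 72 h; on this read-out higher numbers stand for weaker inhibition and lower numbers for stronger inhibition. Compound 1 `COc1ccc2cc(C(C)c3nnc4n3N=C(c3ccc(Cl)cc3Cl)CS4)ccc2c1` gives 10700 nM, compound 2 `COc1ccc(C2=Nn3c(nnc3C(C)c3ccc4cc(OC)ccc4c3)SC2)cc1` gives 8500 nM, and compound 3 `COc1ccc2cc(C(C)c3nnc4n3N=C(c3ccc(Cl)cc3)CS4)ccc2c1` gives 5600 nM, the lowest of the three numbers, though its gaps to compound 2 and to compound 1 both stay within the scatter. Compound 4 `COc1ccc2cc(C(C)c3nnc4n3N=C(c3ccc(C)cc3)CS4)ccc2c1` differs from compound 3 by methyl in place of chloro on an aromatic carbon. Among the compounds with values here, two measured steps concern that same phenyl ring: a 1.5-fold lower number from compound 2 to compound 3 (0.18 log units; within the scatter) and a 1.9-fold lower number from compound 1 to compound 3 (0.28 log units; within the scatter), each within the scatter. In this assay the step from compound 3 to compound 4 is therefore expected to stay within the scatter as well, estimated as a 1.1-fold higher number from compound 3 to compound 4 (0.03 log units; within the scatter). Compound 4 is estimated at 6000 nM, with a range from 2500 nM to 14000 nM.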

Compound 4, half-maximal inhibitory concentration: 8200 nM
Compound 4: middle estimate off by 1.4-fold (0.14 log units), on the low side; the measured number falls inside the stated range.
By their numbers in this assay, from the lowest: compounds 3, 4, 2 and 1 (each within the scatter of the next).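

In this assay, methyl at this position brings no step beyond the scatter against any of the three other phenyl groups: a 1.5-fold higher number from compound 3 to compound 4 (0.17 log units; within the scatter), a 1.0-fold lower number from compound 2 to compound 4 (0.02 log units; within the scatter), and a 1.3-fold lower number from compound 1 to compound 4 (0.12 log units; within the scatter). The four compounds therefore cannot be told apart by these changes, so a carbon-only methyl group here reads the same as chloro, methoxy or the 2,4-dichlorophenyl pattern. No evidence is available to explain this flat result. From the compounds shown here alone, it remains open whether an amine, a carboxylic acid or a longer chain in this place would move the number beyond the scatter.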